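Chloro for Fluoro on a Dichloroacetamide Anilide

A few compounds are considered here, and "the series" means these few. Any claim that something is new, unique, unknown or untested is made for them only; others in the source may bear on it.

Three small anilides of dichloroacetic acid make up this set, and they differ only in one substituent on the aromatic ring. Compound 1, `Cc1cccc(NC(=O)C(Cl)Cl)c1`, carries a methyl group there. In a functional assay on A549 cells (Homo sapiens) for antiproliferative activity, read by MTT assay, with a stated time of 72 h (a lower number here means a stronger inhibitor, a higher number a weaker inhibitor), compound 1 gives 41100 nM, a weak result on this scale. Compound 2, `O=C(Nc1cccc(F)c1)C(Cl)Cl`, carries a fluoro group in the same position. In this assay compound 2 gives "not determined" (no result reported), so there is no single number to place it on the scale, and nothing can be said about how it compares with compound 1.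

Compound 3, `O=C(Nc1cccc(Cl)c1)C(Cl)Cl`, has not been measured yet. It is reached from compound 2 by chloro in place of fluoro on an aromatic carbon. Among the compounds with values here, because no measured pair of this kind is available here, the size and direction of this step cannot be read from the data. Within the data shown here, the only anchor is compound 1, whose 41100 nM sets a weak benchmark for the shared core.

Compound 3 is therefore expected to give about 30000 nM, most likely between 10000 nM and 100000 nM.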

Compound 3, half-maximal inhibitory concentration: 14800 nM
Compound 3: middle estimate off by 2.0-fold (0.31 log units), on the high side; the measured number falls inside the stated range.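

Replacing the methyl group with chloro on the aromatic carbon gives a 2.8-fold lower number from compound 1 to compound 3 (0.44 log units; beyond the scatter) in this assay, which shows that the activity of the shared core does respond to the group at this position, even though compound 3 still needs 14800 nM to reach half-maximal inhibition. Within the data shown here, the swap of fluoro for chloro, the change that leads to compound 3 from compound 2, cannot be read, as compound 2 has no single number in this assay, so the methyl-to-chloro step is the only comparison available on this ring. Nothing shown here gives a reason for the difference between compound 1 and compound 3.

From the compounds shown here alone, it remains open whether a group of a different kind at this position, such as an amine, a carboxylic acid or a longer chain, would lower the number further or raise it again. The compounds shown also leave open whether the step from methyl to chloro would have the same direction and size at another place on the ring or on a different core.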